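A second thiophene ring on the sulfonyl group

The source may hold more compounds than are shown below. What is called first, only, known or untested is meant among the compounds shown, and "the series" means these compounds.

Measured compounds:
compound 1, `CCN(C/C=C/C#CC(C)(C)C)Cc1cccc(OCCN(C)S(=O)(=O)c2cccs2)c1`: 60 nM
compound 2, `CCN(C/C=C/C#CC(C)(C)C)Cc1cccc(OCCN(C)S(=O)(=O)c2ccc(Br)cc2)c1`: 330 nM
compound 3, `CCN(C/C=C/C#CC(C)(C)C)Cc1cccc(OCCN(C)S(=O)(=O)Cc2cccs2)c1`: 200 nM

In a functional assay on HepG2 cells for inhibition of squalene monooxygenase (Homo sapiens) (on this read-out higher numbers stand for weaker inhibition and lower numbers for stronger inhibition), compound 1 stands lowest of the three numbers. Both neighbours are beyond the scatter: a 3.3-fold higher number from compound 1 to compound 3 (0.52 log units; beyond the scatter), and a 5.5-fold higher number from compound 1 to compound 2 (0.74 log units; beyond the scatter). Each of these steps exchanges the thiophen-2-yl on the sulfonyl sulfur for another group, so the read-out is sensitive to what sits on that sulfur.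

Compound 4, `CCN(C/C=C/C#CC(C)(C)C)Cc1cccc(OCCN(C)S(=O)(=O)c2ccc(-c3ccsc3)s2)c1`, keeps the thiophen-2-yl and instead adds to it: thiophen-3-yl in place of hydrogen on an aromatic carbon. For the measured compounds named here, no measured step adds a group to this ring, so neither step bears directly on the change; they only show that alterations around the sulfonyl group cost potency, by moderate amounts. On that basis a modest weakening is expected, with wide uncertainty in either direction, amounting to a 2.5-fold higher number from compound 1 to compound 4 (0.40 log units; beyond the scatter). Compound 4 is therefore estimated at 150 nM, within the range 40 nM to 600 nM.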

Compound 4, half-maximal inhibitory concentration: 210 nM
Estimate against measurement, compound 4: 1.4-fold (0.15 log units) below; low and high end bracket the measured number.
By their numbers in this assay, from the lowest: compound 1; then compounds 3, 4 and 2 (each within the scatter of the next).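

Adding thiophen-3-yl next to the ring sulfur of the thiophen-2-yl gives, in this assay, (a 3.5-fold higher number from compound 1 to compound 4 (0.54 log units; beyond the scatter)), so the read-out responds to substitution on this ring as well as to exchange of the group on the sulfonyl sulfur. The resulting 5-(thiophen-3-yl)thiophen-2-yl group cannot be separated from the other two replacements, with (a 1.1-fold higher number from compound 3 to compound 4 (0.02 log units; within the scatter)) and (a 1.6-fold lower number from compound 2 to compound 4 (0.20 log units; within the scatter)) both within the scatter, and compound 1 keeps the lowest number. Nothing available explains the loss on adding this ring.

Going by these compounds, whether a single methyl group or a chlorine atom at this place would be tolerated remains open, leaving unknown whether the size of the addition matters. Also unresolved is whether an amine or a carboxylic acid on the added ring would change the result.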